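This account rests on a few compounds, and the source may have more. Where it says the series, first, only, none or still open, it means among the compounds named here.

Among the measured compounds shown here, in an ADME assay on microsomes from liver (Rattus norvegicus) for metabolic stability, read by LC-MS, using NADPH, at 37 degrees C (a higher number here means that the compound lasts longer, a lower number that the compound disappears faster), compound 2 `CC[C@@H]1C[C@H](CC)CN(CCCNC(=O)C2CCN(Cc3nc(-c4ccccc4C)oc3C)CC2)C1` gives 0.0917 h, the lowest number among the compounds measured so far. Compound 1 `Cc1ccc(C)c(-c2nc(CN3CCC(C(=O)NCCCN4C[C@H](C)C[C@H](C)C4)CC3)c(C)o2)c1` gives 0.5 h, a higher number by clearly more than the usual scatter, although the two compounds differ in more than one place. Compound 3 `Cc1oc(-c2ccc(Cl)cc2)nc1CN1CCC(C(=O)NCCCN2C[C@H](C)C[C@H](C)C2)CC1` is reported as > 0.5 h, which is a limit of the assay and not a number.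

Compound 4 `Cc1ccccc1-c1nc(CN2CCC(C(=O)NCCCN3CCC(C)CC3)CC2)c(C)o1` differs from compound 2 in one place: 4-methylpiperidin-1-yl in place of 3,5-diethylpiperidin-1-yl on a saturated chain carbon, three bonds along the chain from an amide-type nitrogen. This puts 4-methylpiperidin-1-yl in place of 3,5-diethylpiperidin-1-yl on a saturated chain carbon, three bonds along the chain from an amide-type nitrogen.

For the measured compounds named here, the only measured single-place step is a number no lower from compound 1 to compound 3 (the limit leaves the size open). Its size cannot be read, and it concerns an aromatic carbon elsewhere in the molecule, so it says little about this change. The closest guide is therefore indirect: compound 1 reaches 0.5 h without the 3,5-diethylpiperidin-1-yl group, but its other difference from compound 2 weakens the comparison. A moderate rise is expected on this basis, and the expected step, a 2.2-fold higher number from compound 2 to compound 4 (0.34 log units; beyond the scatter), may not clear the scatter by much. Compound 4 is estimated at 0.2 h, with an expected range from 0.09 h to 0.5 h.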

Compound 4, half-life: > 0.5 h
Compound 4: no number, only a limit; the forecaster's own chance of this, stated with the estimate: 10%; at least 2.5-fold (0.39 log units) between middle value and limit.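

In this assay, putting 4-methylpiperidin-1-yl in place of 3,5-diethylpiperidin-1-yl gives an at least 5.4-fold higher number from compound 2 to compound 4 (0.73 log units; beyond the scatter). Among the compounds shown here, this is the first step with a readable lower size, and it shows that the group on the saturated chain carbon, three bonds along the chain from an amide-type nitrogen, can by itself change how long a compound lasts, with the rest of the molecule kept the same. The earlier single-place step lay on an aromatic carbon elsewhere in the molecule and could not be read, so it gave no such information. The value of compound 4 is a limit of the assay and not a number, so the full size of this step stays unknown: the limit of > 0.5 h in this assay, at which 2 of the 4 values shown sit.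

The change alters the substituents, their places on the ring and the defined stereocentres all at once, so the compounds shown do not separate these contributions. Plain piperidin-1-yl, or morpholin-4-yl, at this same place would test whether the alkyl groups on the ring matter at all, and a value inside the range of the assay would be needed to give the step a size.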